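Swapping a Benzyl for a Sec-Butyl on an Amide Nitrogen

The source may hold more compounds than are shown below. What is called first, only, known or untested is meant among the compounds shown, and "the series" means these compounds.

Of the compounds shown here, three built on a shared core have been measured in an ADME assay on MDCK cells (Canis lupus familiaris) for cytotoxicity, read by microscopy, with a stated time of 72 h; a higher number here means that more compound is tolerated, a lower number that less compound is tolerated. Compound 1, `COC(=O)C[C@H](NC(=O)OC(C)(C)C)C(=O)N(Cc1ccccc1)C1(C(=O)NCc2ccccc2)CCN(Cc2ccccc2)CC1`, gives > 100000 nM in this assay, and this is a limit of the assay rather than a number. Compound 2, `COC(=O)C[C@H](NC(=O)OC(C)(C)C)C(=O)N(Cc1ccc(F)cc1)C1(C(=O)NCc2ccccc2)CCN(C2CCCCC2)CC1`, gives 73000 nM in this assay. Compound 3, `COC(=O)C[C@H](NC(=O)OC(C)(C)C)C(=O)N(Cc1ccc(F)cc1)C1(C(=O)NC2CCCCC2)CCN(Cc2ccccc2)CC1`, gives 100000 nM in this assay. The values of compound 2 and compound 3 lie within the usual scatter of each other, and compound 1 stands at the limit of > 100000 nM in this assay, at which 1 of the 3 values shown sits.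

No two of the measured compounds differ in only one place, so no single measured step can be read from them. Compound 4, `CCC(C)N(C(=O)[C@H](CC(=O)OC)NC(=O)OC(C)(C)C)C1(C(=O)NCc2ccccc2)CCN(Cc2ccccc2)CC1`, has not yet been measured. It differs from compound 1 in one place: sec-butyl in place of benzyl on an amide-type nitrogen. All three measured values sit at or near the top of the range the assay reports. Against that backdrop, the step of a number no higher from compound 1 to compound 4 (the limit leaves the size open) is expected to be small, with no clear direction, and not beyond the scatter. Compound 4 is therefore estimated to give about 100000 nM in this assay, within a range from 50000 nM to 200000 nM, and the reading may again be reported only as a limit.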

Compound 4, minimum cytotoxic concentration: 84000 nM
Beside the measured number, compound 4's estimate is 1.2-fold (0.08 log units) above it; the range from low to high includes it.
By their numbers in this assay, from the lowest: compounds 2, 4 and 3 (each within the scatter of the next).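

In this assay, for the compounds shown here, putting sec-butyl in place of benzyl on this amide-type nitrogen gives an at least 1.1-fold lower number from compound 1 to compound 4 (0.07 log units; that floor lies within the scatter), the first step in this set that can be read across a single change. Compound 4 gives 84000 nM, so a compound without the benzyl at this position, and so without its aromatic ring, still sits high in the range this assay reports, and an open-chain group is tolerated here at that level. The full size of the step stays unknown because compound 1 stands at a limit of the assay rather than at a number: the limit of > 100000 nM in this assay, at which 1 of the 4 values shown sits.

Going by these compounds, whether this position stays as forgiving for groups of a different kind remains open, for example an amine, a carboxylic acid or a longer chain on the same nitrogen. Going by these compounds alone, the result also covers only one change on one core and cannot say whether swapping benzyl for sec-butyl would behave the same way if the other groups on the shared core were different.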